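Swapping the amide aryl group on a thiophene core

The compounds below may be only part of what the source reports. "The series", "measured", "known", "first", "only" and "open" are said of these compounds alone.

Measured compounds:
- compound 1 `COC(=O)c1scc(-c2ccc(NC(=O)c3ccc4ccccc4c3)cc2)c1OC`: 18200 nM
- compound 2 `COC(=O)c1scc(-c2ccc(NC(=O)c3cc(I)ccc3F)cc2)c1OC`: "not determined" (no result reported)

Compound 1, carrying a naphthalene amide on the shared core, is a weak inhibitor in a functional assay on HeLa cells (Homo sapiens) for antiproliferative activity, read by MTT assay, with a stated time of 24 h (a lower number here means a stronger inhibitor, a higher number a weaker inhibitor), where compound 1 gives 18200 nM. Compound 2 carries a 2-fluoro-5-iodophenyl amide on the same core, but in this assay compound 2 is recorded as "not determined" (no result reported) and so has no single number at all, so it stands nowhere on the scale that compound 1 defines; the only measured point in this series is the weak value of compound 1.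

Compound 3 `COC(=O)c1scc(-c2ccc(NC(=O)c3ccc(OC)nc3)cc2)c1OC` is the next step. It differs from compound 2 in one place: 6-methoxypyridin-3-yl in place of 2-fluoro-5-iodophenyl on a carbonyl carbon. For the measured compounds named here, no measured step from compound 2 to compound 3 exists in this assay, and with compound 2 unmeasured the direction of the change cannot be read from data. The best anchor is compound 1, whose value 18200 nM in this assay suggests the series as a whole sits in the weak range, so any step from compound 2 to compound 3 is expected to be modest and its direction uncertain. Compound 3 is therefore estimated at 20000 nM in this assay, with a plausible range from 5000 nM to 80000 nM.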

Compound 3, half-maximal inhibitory concentration: 24400 nM
The estimate for compound 3 lay 1.2-fold (0.09 log units) below the measured number, within the range that was stated.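

In this assay, the group on the carbonyl carbon, whose other neighbour is the amide-type nitrogen, now has two readings, and 6-methoxypyridin-3-yl in place of naphthalen-2-yl gives a 1.3-fold higher number from compound 1 to compound 3 (0.13 log units; within the scatter), a step that lies within the usual scatter of repeated measurements. For the compounds shown here, the earlier compounds offered only one number, so they could not show whether this group had any visible effect, but here two clearly different groups, one of them a ring with a hetero atom and the other built of carbon only, give values that cannot be told apart, and both remain weak. Nothing available explains why these two groups read alike.

Steps involving compound 2 cannot be read, so the place of its 2-fluoro-5-iodophenyl group on this scale stays unknown. The compounds shown also leave open whether a quite different group at this place, such as a ring bearing an amine or a carboxylic acid, or a longer chain, would move the number beyond the scatter and give a stronger inhibitor.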